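Acetylation of the side-chain hydroxy in a lactone series

The source may report more compounds than this note shows. Statements on the series, on what has been measured and on what is new or still open speak of the compounds shown alone.

Compound 1 `CCCC[C@H](O)/C=C\[C@@H]1OC(=O)C=C[C@@H]1OC(C)=O` is the reference point of the pair examined here. In a functional assay on LNCaP cells (Homo sapiens) for cytotoxicity, read by sulforhodamine B assay, with a stated time of 72 h (a higher number here means that more compound is needed for the effect, a lower number that less compound is needed), compound 1 gives 0.9 ug/mL, the lower of the two numbers recorded so far. Compound 2 `CC(=O)O[C@H](/C=C\[C@H]1CC=CC(=O)O1)C[C@@H](OC(C)=O)[C@H](C)OC(C)=O` carries several acetoxy groups on a different side chain and a different core; in this assay compound 2 gives 7.5 ug/mL, a number that lies beyond the scatter from compound 1. Within the data shown here, compound 2 differs from compound 1 in several places at once, so it sets no single step that could guide the present change.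

The compound not yet measured is compound 3 `CCCC[C@@H](/C=C\[C@@H]1OC(=O)C=C[C@@H]1OC(C)=O)OC(C)=O`. Relative to compound 1 it differs as follows: acetyl in place of hydrogen on an oxygen on a saturated carbon. Among the measured compounds shown here, the change is small in atom count, and no measured pair isolates it. In this assay the expected step is modest, toward a somewhat higher number, and may fall within the scatter: a 1.7-fold higher number from compound 1 to compound 3 (0.22 log units; within the scatter). On that basis compound 3 is estimated to give 1.5 ug/mL in this assay, with a range from 0.5 ug/mL to 4.5 ug/mL.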

Compound 3, concentration for half-maximal effect: 0.7 ug/mL
Compound 3: the middle estimate sits 2.1-fold (0.33 log units) above what was measured; measured number inside the range.
By their numbers in this assay, from the lowest: compounds 3 and 1 (each within the scatter of the next); then compound 2.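

Acetyl in place of hydrogen on an oxygen on a saturated carbon, the hydroxy to acetoxy change, gives a 1.3-fold lower number from compound 1 to compound 3 (0.11 log units; within the scatter) in this assay and is the only step in the series that isolates one place. Within this pair, a free hydroxy at this position is therefore not needed to keep the number within the scatter, and compound 3 cannot be told apart from compound 1 in this read-out. No measurement on hand bears on why the step is so small.

Among these compounds, compound 2 differs from compound 1 in several places and supplies no matching step, so it remains open whether the same change would be tolerated on a different core or side chain. Also open, as far as these compounds go, is whether other groups on this oxygen, such as a benzoyl ester or a methyl ether, or an amine in place of the oxygen, would stay within the scatter, and what the second acetoxy already present on the core of compound 1 contributes to the number.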